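Swapping the aryl group on the cinnamoyl-type chain

The source may hold more compounds than are shown below. What is called first, only, known or untested is meant among the compounds shown, and "the series" means these compounds.

Of the compounds shown here, three sharing one core have been measured in a functional assay (Homo sapiens), tested at 10 uM; on this read-out higher numbers stand for a weaker effect at the one concentration tested and lower numbers for a stronger effect. Compound 1 `O=C(/C=C/c1ccccc1)N1CCc2c(Cl)c(O)c(O)c(Cl)c2C1` gives 41%, compound 2 `O=C(CCCc1ccc(Cl)cn1)N1CCc2c(Cl)c(O)c(O)c(Cl)c2C1` gives 15%, and compound 3 `O=C(/C=C/c1cccnc1)N1CCc2c(Cl)c(O)c(O)c(Cl)c2C1` gives 44%. Compound 3 thus shows the highest of the three numbers, but compound 1 sits closest to it, within the scatter, while compound 2 lies well below, beyond the scatter.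

Compound 4 `O=C(/C=C/c1ccc(O)cc1)N1CCc2c(Cl)c(O)c(O)c(Cl)c2C1` differs from compound 3 in one place: 4-hydroxyphenyl in place of pyridin-3-yl on a double-bonded chain carbon bound to a double-bonded chain carbon. Among the measured compounds shown here, the only measured step that bears on such an exchange of the aryl group on the double-bonded chain carbon is a number 3 percentage points higher from compound 1 to compound 3 (within the scatter), a change within the scatter. Compound 2 differs from compound 3 in more than one place, so its lower value gives no guidance on the aryl swap alone. On this basis no step beyond the scatter is expected from compound 3 to compound 4, that is, an expected a number 2 percentage points lower from compound 3 to compound 4 (within the scatter).

Compound 4 is therefore estimated at 42%, in a range from 27% to 57%.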

Compound 4, a percentage reported as activity, at one concentration (the size of the read-out at that concentration, not a potency): 32%
For compound 4 the middle estimate is 10 percentage points above the measured one; the measured number falls inside the stated range.
By their numbers in this assay, from the lowest: compound 2; then compounds 4, 1 and 3 (each within the scatter of the next, the first and the last beyond it).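

At this position, on a double-bonded chain carbon bound to a double-bonded chain carbon, the earlier aryl exchange had stayed within the scatter, whereas 4-hydroxyphenyl in place of pyridin-3-yl gives a number 12 percentage points lower from compound 3 to compound 4 (beyond the scatter) in this assay and so shows that the read-out can respond to the aryl group here, if modestly. Hydroxy in place of hydrogen on an aromatic carbon, however, gives a number 9 percentage points lower from compound 1 to compound 4 (within the scatter) and so does not separate the hydroxylated compound from its unsubstituted phenyl counterpart. Nothing available explains either step.

The compounds shown leave open whether a methoxy group, an amine or a carboxylic acid in place of the hydroxy would follow the same course. They also leave open what the longer chain of compound 2 contributes apart from its chlorinated pyridine ring, as no compound shown changes one of these alone.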